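This account rests on a few compounds, and the source may have more. Where it says the series, first, only, none or still open, it means among the compounds named here.

Of the compounds shown here, three built on a shared core have been measured in an assay on HeLa cells for inhibition of Indoleamine 2,3-dioxygenase 1 (Homo sapiens), read by spectrophotometry, with a stated time of 24 h; a higher number here means that more compound is needed for the effect, a lower number that less compound is needed. Compound 1 `CS(=O)(=O)NNc1nonc1/C(=N/O)Nc1ccc(F)c(Br)c1` reaches only a limit of the assay, > 800 nM (the limit of > 800 nM in this assay, at which 1 of the 3 values shown sits). Compound 2 `NNc1nonc1/C(=N/O)Nc1ccc(F)c(Br)c1` gives 556 nM. Going by the values given here, compound 3 `NS(=O)(=O)NNc1nonc1/C(=N/O)Nc1ccc(F)c(Br)c1` gives 101 nM, the lowest of the two numbers known, and the step of a 5.5-fold lower number from compound 2 to compound 3 (0.74 log units; beyond the scatter) lies beyond the usual scatter, as does an at least 7.9-fold lower number from compound 1 to compound 3 (0.89 log units; beyond the scatter), while an at least 1.4-fold lower number from compound 1 to compound 2 (0.15 log units; that floor lies within the scatter) does not.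

Compound 4 `[O-][S+]1CC(Nc2nonc2/C(=N/O)Nc2ccc(F)c(Br)c2)C1` has not yet been measured. It differs from compound 3 in one place: a group of 5 heavy atoms (3 carbon, 1 oxygen, 1 sulfur; one four-membered non-aromatic ring with 1 hetero atom) in place of a group of 5 heavy atoms (2 nitrogen, 2 oxygen, 1 sulfur; no ring), on a nitrogen on an aromatic ring. Among the compounds with values here, no measured step covers this exchange directly. The step of a 5.5-fold lower number from compound 2 to compound 3 (0.74 log units; beyond the scatter) shows that the sulfamoyl group set compound 3 apart from compound 2, and in compound 4 that group leaves. The change is therefore expected to amount to a 4.0-fold higher number from compound 3 to compound 4 (0.60 log units; beyond the scatter) in this assay. Compound 4 is expected to give about 400 nM, within 120 nM to 1500 nM.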

Compound 4, half-maximal effective concentration: 79 nM
Compound 4: middle estimate off by 5.1-fold (0.70 log units), on the high side; measured number outside the range, below it.
By their numbers in this assay, from the lowest: compounds 4 and 3 (each within the scatter of the next); then compound 2. At a limit, above all of these: compound 1.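

In this assay, the sulfamoylamino group is not required on a nitrogen on an aromatic ring: the group with the four-membered ring does as well, with a 1.3-fold lower number from compound 3 to compound 4 (0.11 log units; within the scatter), although it has 0 hydrogen-bond donors where sulfamoylamino has 2. Compared with the plain core substituent of compound 2, the new group gives a 7.0-fold lower number from compound 2 to compound 4 (0.85 log units; beyond the scatter), so the gain first seen with compound 3 is not confined to the sulfamoyl group. With an at least 10-fold lower number from compound 1 to compound 4 (1.00 log units; beyond the scatter), only a floor can be given, since one end of this step is a limit of the assay: the limit of > 800 nM in this assay, at which 1 of the 4 values shown sits.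

The compounds shown leave open which part of the entering group counts: the sulfur, the oxygen or the four-membered ring itself. A plain cyclobutyl group or an oxetane on this nitrogen would help separate these, and nothing here tells how either would read in this assay.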